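The source may hold more compounds than are shown below. What is called first, only, known or untested is meant among the compounds shown, and "the series" means these compounds.

Measured compounds:
compound 1 `CC(C)(C)c1ccc(C(=O)/C=C/c2ccncc2)cc1` — 47000 nM
compound 2 `O=C(c1ccccc1)c1cccc(-c2cccnc2)c1` — about 100000 nM

Of the compounds shown here, two have been measured in a functional assay with Rattus norvegicus as the target; a lower number here means a stronger inhibitor, a higher number a weaker inhibitor. Compound 1 gives 47000 nM in this assay, and compound 2 gives about 100000 nM. Compound 1 thus has the lowest of the two numbers; compound 2 is the nearest, its number being higher by a gap that lies beyond the usual scatter. Both values are high, so neither compound is a strong inhibitor in this assay.

The next compound in the series is compound 3 `CN(C)c1ccc(C(=O)/C=C/c2ccncc2)cc1`, which has not yet been measured. It differs from compound 1 in one place: dimethylamino in place of tert-butyl on an aromatic carbon. Within the data shown here, no pair of measured compounds shows a step of this kind, so there is nothing in the data to fix its size or direction. The change keeps the core of compound 1 intact and swaps one group for another of similar size at the same aromatic carbon.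

On that basis compound 3 is expected to stay close to compound 1, with a step of a 1.2-fold lower number from compound 1 to compound 3 (0.07 log units; within the scatter) that may fall within the scatter. The estimate for compound 3 in this assay is 40000 nM, within a range of 10000 nM to 150000 nM.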

Compound 3, half-maximal inhibitory concentration: 11000 nM
Beside the measured number, compound 3's estimate is 3.6-fold (0.56 log units) above it; the measured number falls inside the stated range.
By their numbers in this assay, from the lowest: compound 3; then compound 1; then compound 2.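

In this assay, among these compounds, replacing tert-butyl with dimethylamino on this aromatic carbon produces a 4.3-fold lower number from compound 1 to compound 3 (0.63 log units; beyond the scatter), the first step that can be read at a single position. It shows that the number responds to the group held at this carbon, and that this exchange, a modest one, moves it towards stronger inhibition while the core of compound 1 stays unchanged. The entering dimethylamino contains nitrogen and a hydrogen-bond acceptor, whereas the leaving tert-butyl has neither, but no supporting data link the step to either feature or offer any explanation for it.

The compounds shown leave open whether other groups on the same aromatic carbon, such as a primary amine, a methoxy group or a carboxylic acid, would lower the number further, leave it unchanged or raise it. Among the compounds shown here, they also leave open whether this step depends on the rest of the molecule, since this exchange appears in only one pair, and a single pair cannot show whether it would carry over to a different core.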